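Carbamate ester variation on the dimethylaminobiphenyl series

The compounds below may be only part of what the source reports. "The series", "measured", "known", "first", "only" and "open" are said of these compounds alone.

The series shares a biphenyl bearing a dimethylamino group. Compound 1 `CCOC(=O)c1cccc(-c2ccc(N(C)C)cc2)c1` carries an ethyl ester and in an assay on COS-7 cells for inhibition of patatin-like phospholipase domain-containing protein 2 (Mus musculus) (a higher number here means a weaker inhibitor, a lower number a stronger inhibitor), compound 1 gives 40000 nM. Among the compounds with values here, compound 2 `COC(=O)Nc1cccc(-c2ccc(N(C)C)cc2)c1` carries a methyl carbamate instead; in this assay compound 2 gives 5000 nM, the lowest of the two numbers so far. Within the data shown here, the single measured step, an 8.0-fold lower number from compound 1 to compound 2 (0.90 log units; beyond the scatter), shows that the carbamate is the better of the two side chains.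

Compound 3 `CN(C)c1ccc(-c2cccc(NC(=O)Oc3ccccc3)c2)cc1` keeps the carbamate and changes its ester part: phenyl in place of methyl on an oxygen next to a carbonyl group. Among the measured compounds shown here, no measured step touches this oxygen substituent, so the step from compound 1 to compound 2 bears only indirectly, in that the carbamate itself is retained. With nothing to rest on beyond that, a step of size a 1.7-fold lower number from compound 2 to compound 3 (0.22 log units; within the scatter) is expected, within or only modestly beyond the scatter. Compound 3 is therefore estimated at 3000 nM in this assay, with a range from 600 nM to 15000 nM.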

Compound 3, half-maximal inhibitory concentration: 73000 nM
The estimate for compound 3 lay 24-fold (1.39 log units) below the measured number; measured number above the stated range.
By their numbers in this assay, from the lowest: compound 2; then compounds 1 and 3 (each within the scatter of the next).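

In this assay, within the data shown here, phenyl in place of methyl on an oxygen next to a carbonyl group gives a 15-fold higher number from compound 2 to compound 3 (1.16 log units; beyond the scatter) and is the first measured change at this oxygen substituent. The earlier step, an 8.0-fold lower number from compound 1 to compound 2 (0.90 log units; beyond the scatter), concerned the side chain as a whole, whereas this one shows that keeping the carbamate does not by itself keep the value of compound 2 at 5000 nM and that the number depends strongly on what sits on this oxygen. Nothing measured here gives a reason for this step.

Open, as far as these compounds go, is how the number runs between methyl and phenyl on this oxygen, for example with ethyl, isopropyl or a longer chain. Also open, from the compounds shown here alone, is whether benzyl, or an amine-bearing chain such as dimethylaminoethyl, is tolerated at the same place.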